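The source may hold more compounds than are shown below. What is called first, only, known or untested is meant among the compounds shown, and "the series" means these compounds.

Among the measured compounds shown here, compound 2, `CC(C)n1ncc2c(C(=O)NCc3cn(-c4cccc(F)c4)nn3)cccc21`, is one of two compounds tested so far in a functional assay on PC-3 cells (Homo sapiens) for inhibition, read by MTT assay, with a stated time of 72 h; a higher number here means a weaker inhibitor, a lower number a stronger inhibitor. Compound 2 gives 36100 nM, the higher of the two numbers; compound 1, `Cc1ccc(-n2cc(CNC(=O)c3cccc4c3cnn4C(C)C)nn2)c(C)c1`, gives 10600 nM. For the measured compounds named here, the only single change measured so far is a 3.4-fold higher number from compound 1 to compound 2 (0.53 log units; beyond the scatter), so the aromatic ring attached to the triazole nitrogen does shift the result, though only to a modest extent.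

Compound 3, `CC(C)n1ncc2c(C(=O)NCc3cn(-c4ccc([N+](=O)[O-])cc4)nn3)cccc21`, differs from compound 2 by 4-nitrophenyl in place of 3-fluorophenyl on an aromatic nitrogen. Going by the values given here, no measured pair shows this particular exchange, so the step can only be judged against the one measured change on the same position, which was modest in size. A step of similar size in either direction, or none beyond the scatter, is the reasonable expectation. Compound 3 is therefore expected to give about 25000 nM, within a range of 8000 nM to 80000 nM, which means an expected step of a 1.4-fold lower number from compound 2 to compound 3 (0.16 log units; within the scatter).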

Compound 3, half-maximal inhibitory concentration: > 40000 nM
Compound 3: only a limit was reported; the forecaster's own chance of this, stated with the estimate: 15%; at least 1.6-fold (0.20 log units) between middle value and limit.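

In this assay, the result for compound 3 is a limit and not a number, and how far it reaches cannot be told because of that limit: the limit of > 40000 nM in this assay, at which 1 of the 3 values shown sits.

Exchanging the ring gives an at least 1.1-fold higher number from compound 2 to compound 3 (0.04 log units; that floor lies within the scatter), so 4-nitrophenyl and 3-fluorophenyl cannot be ranked against each other here. The second comparison gives an at least 3.7-fold higher number from compound 1 to compound 3 (0.57 log units; beyond the scatter), so both rings now tried in place of 2,4-dimethylphenyl on this aromatic nitrogen give a weaker inhibitor, and none of the three compounds goes against this.

Going by these compounds, it stays open whether either methyl group of 2,4-dimethylphenyl alone would keep the result of compound 1. Also open, on these data alone, is how a phenyl ring carrying an amine or a carboxylic acid, or a butyl chain in place of the ring, would read in this assay.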